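The compounds below may be only part of what the source reports. "The series", "measured", "known", "first", "only" and "open" are said of these compounds alone.

The measured compounds are:

Compound 1, `COc1ccc(C(=O)NC[C@H]2c3[nH]c4ccccc4c3C[C@H]3[C@H]4c5[nH]c6ccccc6c5C[C@@H]([C@H](C#N)N23)N4C)cc1`: 320 nM
Compound 2, `CN1[C@@H]2c3[nH]c4ccccc4c3C[C@H]1[C@H](C#N)N1[C@@H](CNC(=O)c3ccc(F)cc3)c3[nH]c4ccccc4c3C[C@@H]21`: 250 nM

Both were tested in a functional assay on A2780 cells (Homo sapiens) for cytotoxicity, read by MTT assay, with a stated time of 72 h; on this read-out higher numbers stand for weaker inhibition and lower numbers for stronger inhibition. Compound 1 gives 320 nM in this assay, and compound 2 gives 250 nM. For the measured compounds named here, the only measured step is a 1.3-fold lower number from compound 1 to compound 2 (0.11 log units; within the scatter), so compound 2 holds the smaller of the two numbers, yet the gap to compound 1 lies within the scatter and the two cannot be separated.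

Compound 3, `CCc1ccc(C(=O)NC[C@H]2c3[nH]c4ccccc4c3C[C@H]3[C@H]4c5[nH]c6ccccc6c5C[C@@H]([C@H](C#N)N23)N4C)cc1`, differs from compound 2 in one place: ethyl in place of fluoro on an aromatic carbon. Going by the values given here, the one step that bears on this position, from methoxy to fluoro, stayed within the scatter. Nothing in the data points to a shift beyond that range when ethyl takes the place of fluoro. The step of a 1.2-fold higher number from compound 2 to compound 3 (0.08 log units; within the scatter) is therefore expected to stay within the scatter. Compound 3 is expected to give about 300 nM in this assay, with a range from 130 nM to 700 nM.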

Compound 3, half-maximal inhibitory concentration: 670 nM
The estimate for compound 3 lay 2.2-fold (0.35 log units) below the measured number, and the stated range covers the measured number.
By their numbers in this assay, from the lowest: compounds 2 and 1 (each within the scatter of the next); then compound 3.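

In this assay, the aromatic carbon para to a large group proves sensitive to what it carries, which the methoxy-to-fluoro step could not show: ethyl in place of fluoro gives a change beyond the scatter (a 2.7-fold higher number from compound 2 to compound 3 (0.43 log units; beyond the scatter)), and so does ethyl in place of methoxy (a 2.1-fold higher number from compound 1 to compound 3 (0.32 log units; beyond the scatter)). Both steps are modest and point the same way, so among these three compounds ethyl alone stands apart, on the side of weaker inhibition, while methoxy and fluoro remain inseparable. Nothing available here explains this shift.

On these data alone, whether a methyl group or a longer chain such as propyl at this carbon would follow ethyl remains open. As far as these compounds go, it is also open how chloro, an amine or a carboxylic acid at the same place would read out.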